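Working notes on a small Toll-like receptor 9 antagonist series

This account rests on a few compounds, and the source may have more. Where it says the series, first, only, none or still open, it means among the compounds named here.

Measured so far:
compound 1 `CCN1CCN(CCCn2cnc3c(N4CCN(CC)CC4)nc(N)nc32)CC1` — 260 nM
compound 2 `CCN1CCN(CCCn2cnc3c(N4CCN(CC)CC4)nc(NCc4ccc(F)cc4)nc32)CC1` — 470 nM
compound 3 `CCN1CCN(CCCn2cnc3c(N4CCN(C(=O)C5CCCC5)CC4)nc(NCc4ccc(F)cc4)nc32)CC1` — > 30000 nM, a limit of the assay rather than a number

Three compounds have been run in an assay on HEK293 cells for antagonist activity at Toll-like receptor 9 (Homo sapiens), read by spectrophotometry; a lower number here means a stronger inhibitor, a higher number a weaker inhibitor. Compound 1 gives 260 nM, and compound 2 gives 470 nM. For compound 3 this assay reports only a limit, > 30000 nM, and no number.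

The change from compound 2 to compound 1 is hydrogen in place of 4-fluorobenzyl on a nitrogen on an aromatic ring. It makes a 1.8-fold lower number from compound 2 to compound 1 (0.26 log units; within the scatter). The cores of compound 2 and compound 3 differ by cyclopentylcarbonyl in place of ethyl on an amine nitrogen in a ring, and this change makes an at least 63-fold higher number from compound 2 to compound 3 (1.80 log units; beyond the scatter), with compound 3 sitting at the limit of > 30000 nM in this assay, at which 1 of the 3 values shown sits.

Compound 4 `CCN1CCN(CCCn2cnc3c(N4CCN(C(=O)C5CCCC5)CC4)nc(N)nc32)CC1` is not yet measured. It differs from compound 3 by hydrogen in place of 4-fluorobenzyl on a nitrogen on an aromatic ring, the same change, at the same place, as from compound 2 to compound 1. The expected step from compound 3 to compound 4 in this assay is a number no higher from compound 3 to compound 4 (the limit leaves the size open), resting on the step of a 1.8-fold lower number from compound 2 to compound 1 (0.26 log units; within the scatter) seen for compound 1 and on compound 3 standing at the limit of > 30000 nM in this assay, at which 1 of the 3 values shown sits, so a further limit is likely. Compound 4 is estimated at 30000 nM, expected somewhere between 10000 nM and 100000 nM.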

Compound 4, half-maximal inhibitory concentration: > 30000 nM
Compound 4: a limit, no number; the forecaster's own chance of this, stated with the estimate: 70%; the middle value lies on the limit itself.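

In this assay, cyclopentylcarbonyl in place of ethyl on an amine nitrogen in a ring gives an at least 110-fold higher number from compound 1 to compound 4 (2.06 log units; beyond the scatter), so the large rise seen on the core bearing 4-fluorobenzyl also appears on the core bearing hydrogen at that nitrogen: the same change on two cores in this assay, an at least 63-fold higher number (1.80 log units; beyond the scatter) from compound 2 to compound 3 and an at least 110-fold higher number (2.06 log units; beyond the scatter) from compound 1 to compound 4; the limit leaves it open whether they differ. Compound 4 gives > 30000 nM, which is a limit of the assay and not a number, and the step between compound 3 and compound 4 cannot be read: the limit of > 30000 nM in this assay, at which 2 of the 4 values shown sit. The direction of the change therefore carries across these two cores, but its true size on either core is not shown, nor is any effect of hydrogen in place of 4-fluorobenzyl once cyclopentylcarbonyl is present.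

On these data alone, it remains open whether a smaller acyl group such as acetyl, or a cyclopentyl group without the carbonyl, on the same nitrogen would keep values close to those of compound 1 and compound 2. As far as these compounds go, how a longer alkyl chain such as propyl in place of ethyl would behave at that nitrogen is also open.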